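One Ring Swapped on Compound 1

The compounds below may be only part of what the source reports. "The series", "measured", "known", "first", "only" and "open" are said of these compounds alone.

In a functional assay on HeLa cells (Homo sapiens) for antiproliferative activity, read by MTT assay, with a stated time of 48 h (on this read-out lower numbers stand for stronger inhibition and higher numbers for weaker inhibition), compound 1 `C#Cc1cccc(Nc2ncnc3cc(NC(=O)/C=C/c4ccccc4)sc23)c1` gives 20500 nM. Compound 2 `O=C(/C=C/c1ccc(O)cc1)Nc1cc2c(Nc3ccc(Cl)c(Cl)c3)ncnc2s1`, at 24800 nM, sits level with it within the scatter. Compound 3 `O=C(/C=C/c1ccccc1)Nc1cc2c(Nc3ccc(F)c(Cl)c3)ncnc2s1` gives 2140 nM, a clearly lower number and so stronger inhibition than compound 1.

Compound 4 `O=C(/C=C/c1ccccc1)Nc1cc2ncnc(Nc3ccc(F)c(Cl)c3)c2s1` has not yet been measured in this assay. It keeps the core and the amide side chain of compound 1 and changes a single group: 3-chloro-4-fluorophenyl in place of 3-ethynylphenyl on a nitrogen on an aromatic ring. In words, 3-chloro-4-fluorophenyl sits in place of 3-ethynylphenyl on a nitrogen on an aromatic ring.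

For the measured compounds named here, no measured pair differs in just one place, so the size of this step can only be judged indirectly. Compound 3 is the closest guide, since it carries the same 3-chloro-4-fluorophenyl group and the same amide side chain. Its core, however, is arranged differently from that of compound 4, so the guide is only partial. A lower number is therefore expected, covering only part of the gap down to compound 3, and the estimated change is a 3.4-fold lower number from compound 1 to compound 4 (0.53 log units; beyond the scatter). Compound 4 is estimated at 6000 nM, with the measurement expected to fall between 1500 nM and 24000 nM.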

Compound 4, half-maximal inhibitory concentration: 2810 nM
Beside the measured number, compound 4's estimate is 2.1-fold (0.33 log units) above it; low and high end bracket the measured number.
By their numbers in this assay, from the lowest: compounds 3 and 4 (each within the scatter of the next); then compounds 1 and 2 (each within the scatter of the next).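

In this assay, putting 3-chloro-4-fluorophenyl in place of 3-ethynylphenyl on a nitrogen on an aromatic ring gives a 7.3-fold lower number from compound 1 to compound 4 (0.86 log units; beyond the scatter), and this is the first change in a single place among these compounds. It shows that, with the core and the amide side chain held fixed, this group alone can shift the number beyond the scatter, towards stronger inhibition. The two groups match in what is counted, each with 8 heavy atoms, one six-membered aromatic ring and no hydrogen-bond donors or acceptors, so the shift comes with a change of atoms, a triple bond leaving and fluorine and chlorine entering, and nothing measured here says why it happens.

The compounds shown leave open whether the chlorine, the fluorine or the pair goes with the lower number, a question that 3-chlorophenyl, 4-fluorophenyl or plain phenyl on the same nitrogen would address. On these data alone, it also remains open whether the same swap would have a similar effect with a different side chain in place of the amide, such as a simple acetamide.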